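Ester variation on the shared core: expected cytotoxicity of compound 4

The compounds below may be only part of what the source reports. "The series", "measured", "known", "first", "only" and "open" are said of these compounds alone.

Measured compounds:
compound 1, `O=CCc1c(-c2ccccc2Cl)c2cc(Cl)ccc2[nH]c1=O`, 120000 nM
compound 2, `CC(=O)OCC(=O)OCCc1c(-c2ccccc2Cl)c2cc(Cl)ccc2[nH]c1=O`, 100000 nM
compound 3, `O=C(CN1C(=O)c2ccccc2C1=O)OCCc1c(-c2ccccc2Cl)c2cc(Cl)ccc2[nH]c1=O`, 960000 nM

In an ADME assay on HepG2 2.2.15 cells (Homo sapiens) for cytotoxicity (on this read-out higher numbers stand for lower toxicity in this test and lower numbers for higher toxicity in this test), compound 2 gives the lowest of the three numbers; compound 1 lies within the scatter of it, while compound 3 stands clearly higher. Compound 4, `C/C=C/C(=O)OCCc1c(-c2ccccc2Cl)c2cc(Cl)ccc2[nH]c1=O`, differs from compound 2 by prop-1-en-1-yl in place of acetoxymethyl on a carbonyl carbon. For the measured compounds named here, two measured steps bear on this position: a 1.2-fold lower number from compound 1 to compound 2 (0.08 log units; within the scatter), and a 9.6-fold higher number from compound 2 to compound 3 (0.98 log units; beyond the scatter). The larger step came with a much larger entering group than the one here; the change to compound 4 is closer in size to the first step. The account therefore expects a step of a 1.1-fold higher number from compound 2 to compound 4 (0.04 log units; within the scatter), not beyond the scatter. Compound 4 is estimated at 110000 nM, in the range 50000 nM to 250000 nM.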

Compound 4, half-maximal cytotoxic concentration: 30000 nM
The estimate for compound 4 lay 3.7-fold (0.56 log units) above the measured number; measured number below the stated range.
By their numbers in this assay, from the lowest: compound 4; then compounds 2 and 1 (each within the scatter of the next); then compound 3.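

In this assay the position on this carbonyl carbon responds to a small exchange: prop-1-en-1-yl in place of acetoxymethyl gives a 3.3-fold lower number from compound 2 to compound 4 (0.52 log units; beyond the scatter) and moves the number beyond the scatter. Compound 4 also stands clear of the other two, with a 32-fold lower number from compound 3 to compound 4 (1.51 log units; beyond the scatter) and a 4.0-fold lower number from compound 1 to compound 4 (0.60 log units; beyond the scatter) as further steps, so it now has the lowest number of the four. The compounds shown leave open whether a saturated propyl chain or an aminomethyl group on this carbonyl carbon would read like prop-1-en-1-yl or like acetoxymethyl. Nothing measured here accounts for the shift.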